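The source may report more compounds than this note shows. Statements on the series, on what has been measured and on what is new or still open speak of the compounds shown alone.

Compound 2 `c1ccc(Cc2nnc(-c3c[nH]c4ccccc34)o2)cc1` carries a benzyl group on the shared core. In a functional assay on LNCaP cells (Homo sapiens) for cytotoxicity, read by MTT assay (a higher number here means a weaker inhibitor, a lower number a stronger inhibitor), compound 2 gives > 1000000 nM, which is a limit of the assay rather than a number. Compound 1 `c1ccc(-c2nnc(-c3c[nH]c4ccccc34)o2)cc1` likewise gives > 1000000 nM, again only a limit. The step that the two limits leave unreadable from compound 1 to compound 2 therefore cannot be sized, as the limit of > 1000000 nM in this assay, at which 2 of the 2 values shown sit, shows. Compound 3 `c1ccc2c(-c3nnc(-c4ccncc4)o3)c[nH]c2c1` differs from compound 2 by pyridin-4-yl in place of benzyl on an aromatic carbon. Among the compounds with values here, no measured step bears on this change, so neither direction nor size is readable from the data. Compound 3 is expected to give about 1000000 nM, with a range from 300000 nM to 3000000 nM. The expected step of a number no higher from compound 2 to compound 3 (the limit leaves the size open) is thus estimated as none beyond the scatter.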

Compound 3, half-maximal inhibitory concentration: 10000 nM
The estimate for compound 3 lay 100-fold (2.00 log units) above the measured number; measured number below the stated range.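

At this place on the shared core, the choice of ring does change the result in this assay. Pyridin-4-yl gives an at least 100-fold lower number from compound 2 to compound 3 (2.00 log units; beyond the scatter), and replacing phenyl with it gives an at least 100-fold lower number from compound 1 to compound 3 (2.00 log units; beyond the scatter). Only the ring with a nitrogen comes off the limit, and the phenyl and benzyl compounds stay there, so the full size of both steps remains unknown: the limit of > 1000000 nM in this assay, at which 2 of the 3 values shown sit.

Whether the ring nitrogen itself accounts for the lower number remains open. So does what an amine or a carboxylic acid at this place would give.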